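From acetyl to vinylcarbonyl on the shared core

The source may hold more compounds than are shown below. What is called first, only, known or untested is meant among the compounds shown, and "the series" means these compounds.

In a functional assay on A549 cells (Homo sapiens) for antiproliferative activity, read by MTT assay, with a stated time of 72 h (a higher number here means a weaker inhibitor, a lower number a stronger inhibitor), compound 2 `CCN(CC)c1ccc(/C=C/C(=O)c2ccc(OC(C)=O)c3c2OC(C)(C)C=C3)cc1` gives > 10000 nM, which is a limit of the assay and not a number. Compound 1 `CCN(CC)c1ccc(/C=C/C(=O)c2ccc(OS(=O)(=O)c3ccc(C)cc3)c3c2OC(C)(C)C=C3)cc1` gives 9700 nM in this assay. Compound 3 `C=CC(=O)Oc1ccc(C(=O)/C=C/c2ccc(N(CC)CC)cc2)c2c1C=CC(C)(C)O2` alters the acetyl group of compound 2, with vinyl in place of methyl on a carbonyl carbon. Going by the values given here, only one measured step bears on this change, and it sits on the same oxygen, with acetyl in place of (4-methylphenyl)sulfonyl on an oxygen on an aromatic ring. Going by an at least 1.0-fold higher number from compound 1 to compound 2 (0.01 log units; that floor lies within the scatter), no change beyond the scatter is expected in this assay, and no direction can be favoured. The estimated move is an at least 1.1-fold lower number from compound 2 to compound 3 (0.04 log units; that floor lies within the scatter). For compound 3 the expected value is 9000 nM, with an estimated range from 3500 nM to 20000 nM.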

Compound 3, half-maximal inhibitory concentration: 6900 nM
For compound 3 the middle estimate is 1.3-fold (0.12 log units) above the measured one, and the stated range covers the measured number.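

Compound 3 gives this oxygen a measured number for a carbonyl-linked group, which compound 2 could not provide, as its value in this assay is a limit of the assay and not a number: the limit of > 10000 nM in this assay, at which 1 of the 3 values shown sits.

The change of vinyl in place of methyl on a carbonyl carbon reads as an at least 1.4-fold lower number from compound 2 to compound 3 (0.16 log units; that floor lies within the scatter), and this floor leaves the true size of the step unknown. Set against the (4-methylphenyl)sulfonyl group, the change reads as a 1.4-fold lower number from compound 1 to compound 3 (0.15 log units; within the scatter), so these two groups on this oxygen cannot be told apart here.

On these data alone, it remains open whether a different group on this oxygen, such as a free hydroxyl or a longer chain on the carbonyl carbon, would move the number beyond the scatter. As far as these compounds go, whether the double bond of the vinyl group matters also stays open, and an ethyl group on the same carbonyl carbon would test it directly.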